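Swapping Fluoro for Methoxycarbonyl at the Limit of Measurement

The source may report more compounds than this note shows. Statements on the series, on what has been measured and on what is new or still open speak of the compounds shown alone.

In an ADME assay on HepG2 cells (Homo sapiens) for cytotoxicity, with a stated time of 72 h (on this read-out lower numbers stand for an effect already at smaller amounts and higher numbers for an effect only at larger amounts of compound), compound 1 (`Cc1cc(NC(=O)Nc2cccc([N+](=O)[O-])c2)c2ccccc2n1`) gives > 25000 nM, which is a limit of the assay and not a number. Compound 2 (`Cc1cc(NC(=O)Nc2cccc(F)c2)c2ccccc2n1`) gives > 25000 nM, again only a limit. The two compounds therefore share one ceiling: the limit of > 25000 nM in this assay, at which 2 of the 2 values shown sit.

Compound 3 (`COC(=O)c1cccc(NC(=O)Nc2cc(C)nc3ccccc23)c1`) keeps the shared core of compound 2 and changes one group: methoxycarbonyl in place of fluoro on an aromatic carbon.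

Among the compounds with values here, the only measured step that bears on this change is a step that the two limits leave unreadable from compound 1 to compound 2. It offers no size to carry over, so no step beyond the usual scatter is expected in this assay, and another limit is the most likely report. The estimated value for compound 3 is 25000 nM, within an expected range of 12000 nM to 50000 nM. This estimate corresponds to an expected a number no higher from compound 2 to compound 3 (the limit leaves the size open).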

Compound 3, half-maximal effective concentration: 23000 nM
Compound 3: middle estimate off by 1.1-fold (0.04 log units), on the high side; low and high end bracket the measured number.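

Within the data shown here, compound 3 is the first compound here to give a real number rather than a limit in this assay, so this position on the aromatic ring can carry a group that yields a measurable read-out. Putting methoxycarbonyl in place of fluoro gives an at least 1.0-fold lower number from compound 2 to compound 3 (0.03 log units; that floor lies within the scatter), and putting it in place of nitro gives an at least 1.0-fold lower number from compound 1 to compound 3 (0.03 log units; that floor lies within the scatter). Each size is only a floor, so the true size of both steps stays unknown, and the other compounds remain at the ceiling: the limit of > 25000 nM in this assay, at which 2 of the 3 values shown sit.

The compounds shown leave open whether an amine or a carboxylic acid at this same place would also give a real number, and how large any step would be. They also leave open whether an ester with a longer chain would behave like methoxycarbonyl.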